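From Ethoxycarbonyl to Isopropoxycarbonyl on the Chain

A few compounds are considered here, and "the series" means these few. Any claim that something is new, unique, unknown or untested is made for them only; others in the source may bear on it.

In a physicochemical assay for solubility, in phosphate buffer, with a stated time of 18 h, at pH 7.4 (a higher number here means a more soluble compound, a lower number a less soluble compound), compound 1 `COc1cc2ncnc(-n3nc(-c4ccccn4)nc3N)c2cc1OCCCN(C)C` gives 53000 nM, while compound 2 `CCOC(=O)NCCCOc1cc2c(-n3nc(-c4ccccn4)nc3N)ncnc2cc1OC` gives 16000 nM, the lower of the two numbers. Compound 3 `COc1cc2ncnc(-n3nc(-c4ccccn4)nc3N)c2cc1OCCCNC(=O)OC(C)C` differs from compound 2 by methyl in place of hydrogen on a saturated chain carbon bound to an oxygen next to a carbonyl group and a saturated chain carbon, which turns ethoxycarbonyl into isopropoxycarbonyl. Among the measured compounds shown here, only one measured step bears on this change, and only loosely: a 3.3-fold lower number from compound 1 to compound 2 (0.52 log units; beyond the scatter). For the measured compounds named here, that step exchanged dimethylamino for (ethoxycarbonyl)amino, and no measured pair isolates the added methyl. A slightly lower number, not clearly beyond the scatter, is therefore expected, with an estimated step of a 1.3-fold lower number from compound 2 to compound 3 (0.12 log units; within the scatter). For compound 3 the estimated value is 12000 nM, with an expected range of 5000 nM to 25000 nM.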

Compound 3, solubility: 18000 nM
Beside the measured number, compound 3's estimate is 1.5-fold (0.18 log units) below it; low and high end bracket the measured number.
By their numbers in this assay, from the lowest: compounds 2 and 3 (each within the scatter of the next); then compound 1.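

The methyl that turns ethoxycarbonyl into isopropoxycarbonyl gives a 1.1-fold higher number from compound 2 to compound 3 (0.05 log units; within the scatter) in this assay, so at this position the added carbon shifts the read-out by no more than the scatter. The exchange of dimethylamino for (isopropoxycarbonyl)amino gives a 2.9-fold lower number from compound 1 to compound 3 (0.47 log units; beyond the scatter), so the separation from compound 1 holds for both of these chains. Nothing available here accounts for either step. Still open, on these data alone, is how a tert-butoxycarbonyl group or a longer chain on that oxygen would read, and whether a primary amine or carboxylic acid at the chain end would read closer to compound 1.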